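A few compounds are considered here, and "the series" means these few. Any claim that something is new, unique, unknown or untested is made for them only; others in the source may bear on it.

Measured so far:
Compound 1, `CCCCOc1ccc(C(CC)NC(=O)Oc2cccc(C(F)(F)F)c2)cc1`, in an assay on H4 cells for inhibition of Fatty-acid amide hydrolase 1 (Homo sapiens) (a higher number here means a weaker inhibitor, a lower number a stronger inhibitor), compound 1 gives 51 nM.
Compound 2, `CCCCOc1ccc(C(CC)NC(=O)Oc2cccc(N(C)C)c2)cc1`, in this assay compound 2 gives 54 nM.

Compound 2 stands beside compound 1 on these two numbers: the step of a 1.1-fold higher number from compound 1 to compound 2 (0.02 log units; within the scatter) lies within the scatter, so the two values cannot be told apart. The unmeasured compound 3, `CCCCOc1ccc(C(CC)NC(=O)Oc2ccc(OC)cc2)cc1`, differs from compound 2 in one place: 4-methoxyphenyl in place of 3-(dimethylamino)phenyl on an oxygen next to a carbonyl group. For the measured compounds named here, only one measured step bears on this part of the molecule, the exchange of the group on the aromatic ring carried by the carbamate oxygen, a 1.1-fold higher number from compound 1 to compound 2 (0.02 log units; within the scatter), and it was without effect beyond the scatter. Going by the values given here, compound 3 replaces that whole ring with one that carries a methoxy group at a different position, so the step from compound 2 to compound 3 is larger than the step already seen, and no measured pair shows such a change. Among the compounds with values here, on the one comparison available, the expected step of a 1.4-fold higher number from compound 2 to compound 3 (0.14 log units; within the scatter) is small, with no clear direction. Compound 3 is therefore estimated at 75 nM, within a range from 20 nM to 300 nM.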

Compound 3, half-maximal inhibitory concentration: 12 nM
Compound 3: the middle estimate sits 6.3-fold (0.80 log units) above what was measured; measured number outside the range, below it.
By their numbers in this assay, from the lowest: compound 3; then compounds 1 and 2 (each within the scatter of the next).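

In this assay, putting 4-methoxyphenyl in place of 3-(dimethylamino)phenyl on an oxygen next to a carbonyl group gives a 4.5-fold lower number from compound 2 to compound 3 (0.65 log units; beyond the scatter). This shows that the number can respond to the group at this position, which the earlier exchange, a 1.1-fold higher number from compound 1 to compound 2 (0.02 log units; within the scatter), did not show, as that step stayed within the scatter. The two groups have the same counts of hydrogen-bond donors and acceptors and the same net charge, so those counts do not separate them, and no available evidence accounts for the difference in their numbers.

The step changes both the group on the ring and its place, so the compounds shown leave open whether the lower number belongs to methoxy itself, to where it sits, or to both. They also leave open how far the trend extends along this ring, for instance to an unsubstituted phenyl, or to a ring carrying an ethoxy group, a longer alkoxy chain or a carboxylic acid in place of methoxy.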